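The step from compound 2 to compound 3

The source may report more compounds than this note shows. Statements on the series, on what has been measured and on what is new or still open speak of the compounds shown alone.

Measured in an ADME assay on a cell-free system (plasma, Rattus norvegicus) for metabolic stability, read by LC-MS, with a stated time of 60 min, tested at 100 uM; a lower number here means that less of the compound is left, a higher number that more of the compound is left:
compound 1 `CCCC(=O)c1ccc(OCCCCOc2cc(C(=O)O)ccc2OC)c(C)c1O`: 78%
compound 2 `Cc1c(OCCCCOc2cccc(C(=O)O)c2)ccc(C(=O)CC(C)C)c1C`: 106%

Of these two, compound 2 stands highest at 106%, and the gap to compound 1 lies beyond the scatter. Next comes compound 3 `Cc1c(OCCCCOc2ccccc2C(=O)O)ccc(C(=O)CC(C)C)c1C`, which has the same atoms joined differently: 2-carboxyphenyl in place of 3-carboxyphenyl on an oxygen on a saturated carbon. It carries 2-carboxyphenyl in place of 3-carboxyphenyl on an oxygen on a saturated carbon. Within the data shown here, no measured pair shows this change, so a small fall, within the scatter, is expected. The estimated change is a number 8 percentage points lower from compound 2 to compound 3 (within the scatter). For compound 3 the expected value is 98%, with an estimated range of 80% to 112%.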

Compound 3, percent of the compound remaining: 99%
The estimate for compound 3 lay 1 percentage points below the measured number; the range from low to high includes it.
By their numbers in this assay, from the lowest: compound 1; then compounds 3 and 2 (each within the scatter of the next).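

Among these compounds, this is the first step that differs in one place. In this assay, 2-carboxyphenyl in place of 3-carboxyphenyl on an oxygen on a saturated carbon gives a number 7 percentage points lower from compound 2 to compound 3 (within the scatter) and so, on this core, the read-out does not separate the two arrangements of the same atoms. Nothing measured here offers an explanation for this result. On these data alone, what 4-carboxyphenyl or an unsubstituted phenyl would give at this place stays open. So does whether the same swap would behave alike on the core of compound 1.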